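The source may hold more compounds than are shown below. What is called first, only, known or untested is meant among the compounds shown, and "the series" means these compounds.

Measured so far in a functional assay on MCF7 cells (Homo sapiens) for inhibition, read by MTT assay, with a stated time of 2 days; on this read-out higher numbers stand for weaker inhibition and lower numbers for stronger inhibition:

compound 1 (`Nc1cccc(/C=C/c2ccccc2)c1`): 14 ug/mL
compound 2 (`Nc1cccc(/C=C/c2ccccc2O)c1`): 24.7 ug/mL
compound 3 (`Nc1cccc(/C=C/c2cccc(O)c2)c1`): 54 ug/mL

Compound 1 sits at the low end of these three numbers, with compound 2 within the scatter of it and compound 3 clearly apart. Compound 4 (`Nc1cccc(/C=C/c2ccc(O)cc2)c1`) has not yet been measured. It differs from compound 1 by hydroxy in place of hydrogen on an aromatic carbon, para to a group of 9 heavy atoms: hydroxy in place of hydrogen on an aromatic carbon.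

For the measured compounds named here, two measured steps bear on this change, since compound 2 and compound 3 each carry the same replacement at another place. The first is a 1.8-fold higher number from compound 1 to compound 2 (0.25 log units; within the scatter) and the second is a 3.9-fold higher number from compound 1 to compound 3 (0.59 log units; beyond the scatter), a modest step. Both run towards a higher number, so a higher number is also expected for compound 4 in this assay, of a size similar to these two steps. Two steps are thin ground, however, and neither of them shows the new place itself, so the expectation stays broad. The expected change is a 2.1-fold higher number from compound 1 to compound 4 (0.33 log units; beyond the scatter) and may not clear the scatter. For compound 4 the estimated value is 30 ug/mL, with an expected range from 13 ug/mL to 75 ug/mL.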

Compound 4, half-maximal inhibitory concentration: 6 ug/mL
The estimate for compound 4 lay 5.0-fold (0.70 log units) above the measured number; measured number below the stated range.
By their numbers in this assay, from the lowest: compound 4; then compounds 1 and 2 (each within the scatter of the next); then compound 3.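

In this assay, hydroxy in place of hydrogen on an aromatic carbon, para to a group of 9 heavy atoms, gives a 2.3-fold lower number from compound 1 to compound 4 (0.37 log units; beyond the scatter), whereas the same replacement elsewhere gave a 1.8-fold higher number from compound 1 to compound 2 (0.25 log units; within the scatter) and a 3.9-fold higher number from compound 1 to compound 3 (0.59 log units; beyond the scatter). The direction of this change therefore depends on where the hydroxy sits, and this place is the only one of the three where the number falls, so a result at one place cannot be carried over to another among these compounds. Nothing available here accounts for this reversal.

The compounds shown leave open whether the lower number belongs to hydroxy itself or would also appear with a methoxy group, a fluorine atom or an amine on the same aromatic carbon. They also leave open what a carboxylic acid at this place would give, and whether hydroxy here would give a step in the same direction on a core other than that of compound 1.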